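This account rests on a few compounds, and the source may have more. Where it says the series, first, only, none or still open, it means among the compounds named here.

Series notes on a functional assay on SMMC-7721 cells (Homo sapiens) for inhibition, read by CCK-8 assay; on this read-out lower numbers stand for stronger inhibition and higher numbers for weaker inhibition. Going by the values given here, compound 2 `COc1ccc(-c2nnc(CSc3nnc(/N=C/c4ccccc4O)s3)o2)cc1` stands highest of the two numbers so far: in this assay compound 2 gives 10000 nM. Nearest is compound 1 `Oc1ccccc1/C=N/c1nnc(SCc2nnc(-c3ccccc3)o2)s1`, which in this assay gives 7100 nM; the step of a 1.4-fold higher number from compound 1 to compound 2 (0.15 log units; within the scatter) is methoxy in place of hydrogen on an aromatic carbon and lies within the scatter.

Compound 3 `O=[N+]([O-])c1ccc(-c2nnc(CSc3nnc(/N=C/c4ccccc4O)s3)o2)cc1` differs from compound 2 by nitro in place of methoxy on an aromatic carbon. Among the compounds with values here, the only measured step that bears on this place is the one from compound 1 to compound 2, a substituent exchange at the same aromatic carbon, and it did not move the number beyond the scatter. Within the data shown here, no measured step tests nitro itself. The expectation for compound 3 in this assay is therefore a step of no change at the digits printed from compound 2 to compound 3 (within the scatter), no larger than the scatter, in no settled direction. The estimate for compound 3 is 10000 nM, with a range from 4000 nM to 25000 nM.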

Compound 3, half-maximal inhibitory concentration: 16900 nM
The estimate for compound 3 lay 1.7-fold (0.23 log units) below the measured number; low and high end bracket the measured number.
By their numbers in this assay, from the lowest: compounds 1, 2 and 3 (each within the scatter of the next, the first and the last beyond it).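

In this assay the aromatic carbon para to a large group now shows its first step beyond the scatter: nitro in place of hydrogen gives a 2.4-fold higher number from compound 1 to compound 3 (0.38 log units; beyond the scatter) and this step is modest in size. Nitro in place of methoxy at the same carbon gives a 1.7-fold higher number from compound 2 to compound 3 (0.23 log units; within the scatter) and stays within the scatter, so compound 2 cannot be separated from either compound 1 or compound 3, and only the two ends of this short set differ. Nothing at hand explains the step from hydrogen to nitro.

Going by these compounds, whether the modest step is particular to nitro or would also appear with an amine or a carboxylic acid on this carbon stays open. Also open, on these data alone, is whether nitro elsewhere on the same ring would give a different number.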